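Substituent changes on the aromatic ring: toward compound 4

The source may report more compounds than this note shows. Statements on the series, on what has been measured and on what is new or still open speak of the compounds shown alone.

Measured so far:
compound 1, `CN1CCC[C@H]1COc1cncc(-c2ccccc2)c1`, gives 0.11 nM in an assay on membranes from brain for binding affinity to Neuronal acetylcholine receptor; alpha4/beta2 (Rattus norvegicus); a lower number here means a stronger inhibitor, a higher number a weaker inhibitor
compound 2, `CN1CCC[C@H]1COc1cncc(-c2cccc(N)c2)c1`, gives 0.43 nM in this assay
compound 3, `COc1ccc(-c2cncc(OC[C@@H]3CCCN3C)c2)cc1`, gives 0.32 nM in this assay

Compound 3 holds the second highest of the three numbers. Its nearest neighbour is compound 2, whose value sits within the scatter of it, so no order between compound 2 and compound 3 can be claimed. Compound 1 is the furthest off, with a lower number that lies beyond the scatter.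

Compound 4, `CN1CCC[C@H]1COc1cncc(-c2ccc(C(F)(F)F)cc2)c1`, is the next candidate in this assay. Set against compound 3, the change is trifluoromethyl in place of methoxy on an aromatic carbon.

Among the compounds with values here, two measured steps bear on it, both placing a group on the six-membered aromatic ring of carbon only: a 3.9-fold higher number from compound 1 to compound 2 (0.59 log units; beyond the scatter) and a 2.9-fold higher number from compound 1 to compound 3 (0.46 log units; beyond the scatter). Each entering group raised the number by a modest amount. Within the data shown here, no measured step exchanges one such group for another, so the change from methoxy to trifluoromethyl has no direct precedent here. Taking the two modest rises as the only guide, compound 4 is expected to land near compound 3 or a little higher, with a 1.6-fold higher number from compound 3 to compound 4 (0.19 log units; within the scatter) anticipated. The estimate for compound 4 is 0.5 nM, expected to fall between 0.15 nM and 1.6 nM.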

Compound 4, inhibition constant: 0.15 nM
For compound 4 the middle estimate is 3.3-fold (0.52 log units) above the measured one, and the stated range covers the measured number.
By their numbers in this assay, from the lowest: compounds 1 and 4 (each within the scatter of the next); then compounds 3 and 2 (each within the scatter of the next).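

In this assay, within the data shown here, the place para to a large group on the six-membered aromatic ring of carbon only distinguishes between groups: trifluoromethyl in place of methoxy gives a 2.1-fold lower number from compound 3 to compound 4 (0.33 log units; beyond the scatter) and is the first measured step that exchanges one such group for another rather than replacing hydrogen. Substitution at this place therefore does not always raise the number, since trifluoromethyl in place of hydrogen gives a 1.4-fold higher number from compound 1 to compound 4 (0.13 log units; within the scatter) and no order can be claimed for that pair, whereas methoxy in place of hydrogen at the same place gave a 2.9-fold higher number from compound 1 to compound 3 (0.46 log units; beyond the scatter) as a step beyond the scatter. Nothing available here explains why these two groups differ.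

From the compounds shown here alone, with only methoxy and trifluoromethyl at this place, no rule for the position can be drawn, and it remains open where groups such as a nitrile, a carboxylic acid or a single fluorine atom would fall. Going by these compounds, it is also open whether trifluoromethyl would track with methoxy or amino at the ring carbon that carries amino in compound 2.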